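From compound 1 to compound 4: one added methoxy

This account rests on a few compounds, and the source may have more. Where it says the series, first, only, none or still open, it means among the compounds named here.

In a functional assay on the whole organism with Rattus norvegicus as the target (on this read-out lower numbers stand for an effect already at smaller amounts and higher numbers for an effect only at larger amounts of compound), compound 1 `CCOC(=O)C(=O)Nc1nc(-c2ccccc2OC)cs1` gives > 30 mg/kg, which is a limit of the assay and not a number. Compound 3 `CCOC(=O)C(=O)Nc1nc(-c2ccccc2C(=O)OC)cs1` gives > 10 mg/kg, which is likewise a limit. Compound 2 `CCOC(=O)C(=O)Nc1nc(-c2ccc(NC(=O)C(F)(F)F)cc2)cs1` gives a true number, about 1 mg/kg. As far as these compounds go, the real position of compound 1 therefore remains open, and it is known only by its limit.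

Compound 4 `CCOC(=O)C(=O)Nc1nc(-c2ccc(OC)cc2OC)cs1` keeps the core of compound 1 and differs from it in one place, (methoxy in place of hydrogen on an aromatic carbon). This is methoxy in place of hydrogen on an aromatic carbon, meta to a methoxy group and para to a large group. Within the data shown here, the only measured step that starts from compound 1 is a step that the two limits leave unreadable from compound 1 to compound 3, with methoxycarbonyl in place of methoxy on an aromatic carbon. Among the measured compounds shown here, that step has no readable size, and no measured step shows what an added methoxy does.

The expectation thus rests mainly on compound 1, whose value of > 30 mg/kg is a limit. The estimated step of an at least 1.2-fold lower number from compound 1 to compound 4 (0.07 log units; that floor lies within the scatter) is expected to be modest and towards smaller amounts, and a further limit would be no surprise. For compound 4 the estimate is 25 mg/kg, with an expected range from 6 mg/kg to 60 mg/kg.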

Compound 4, dose for half-maximal effect: > 30 mg/kg
Compound 4 ended at the assay's limit (the forecaster's own chance of this, stated with the estimate: 60%); middle value at least 1.2-fold (0.07 log units) away from the limit.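

In this assay compound 4 gives > 30 mg/kg, which is a limit of the assay and not a number. Compound 1 gives > 30 mg/kg, likewise a limit, and the step between compound 1 and compound 4 cannot be read. The compounds shown leave open whether the added methoxy changes the result in this assay at all.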